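Cyano added to compound 1: expected effect in the series

A few compounds are considered here, and "the series" means these few. Any claim that something is new, unique, unknown or untested is made for them only; others in the source may bear on it.

Measured so far:
compound 1, `CC1(C)CC(=O)c2ccc(NCc3ccccc3)nc2C1`, 45000 nM
compound 2, `CC1(C)CC(=O)c2cc(C#N)c(SCc3ccccc3)nc2C1`, 4800 nM
compound 3, `N#Cc1cc2c(nc1NC1CCCCCC1)CCCC2=O`, 7400 nM

In an in vitro functional assay on cells for antagonist activity at metabotropic glutamate receptor 1 (Rattus norvegicus), read by inositol phosphate accumulation (on this read-out higher numbers stand for weaker inhibition and lower numbers for stronger inhibition), compound 1 gives 45000 nM, the highest of the three numbers. Compound 3 sits at 7400 nM, beyond the scatter below compound 1. Compound 2 sits at 4800 nM, further below still and also beyond the scatter. Among the compounds with values here, both of these lower compounds carry a cyano on the shared core, but each also differs from compound 1 elsewhere, so no measured pair isolates that single change.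

Compound 4, `CC1(C)CC(=O)c2cc(C#N)c(NCc3ccccc3)nc2C1`, differs from compound 1 by cyano in place of hydrogen on an aromatic carbon. Because compound 2 at 4800 nM and compound 3 at 7400 nM both carry the cyano and both lie well below compound 1, the expectation is a move to a lower number, beyond the scatter, in this assay. The expected step from compound 1 to compound 4 is a 5.6-fold lower number from compound 1 to compound 4 (0.75 log units; beyond the scatter). Compound 4 is accordingly estimated at 8000 nM in this assay, with a range from 2500 nM to 25000 nM.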

Compound 4, half-maximal inhibitory concentration: 2500 nM
Estimate against measurement, compound 4: 3.2-fold (0.51 log units) above, and the stated range covers the measured number.
By their numbers in this assay, from the lowest: compounds 4, 2 and 3 (each within the scatter of the next, the first and the last beyond it); then compound 1.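

In this assay, within the data shown here, this is the one pair that isolates the cyano, and the change alone gives an 18-fold lower number from compound 1 to compound 4 (1.26 log units; beyond the scatter) with everything else held as in compound 1. The aromatic carbon two atoms from the ring nitrogen, ortho to a group of 8 heavy atoms, is therefore a position where replacing hydrogen strongly changes the read-out. Nothing shown explains the size of this step.

As far as these compounds go, whether a carboxylic acid, a primary amide or a chlorine atom at this position would match the cyano remains open. From the compounds shown here alone, the cyano step is also read on this single pair, so whether it carries over to the sulfur-linked benzyl group of compound 2 or the ring amine of compound 3 remains unknown.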